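A few compounds are considered here, and "the series" means these few. Any claim that something is new, unique, unknown or untested is made for them only; others in the source may bear on it.

Working notes on the series in a functional assay on K-562R cells (Homo sapiens) for cytotoxicity, read by MTT assay, with a stated time of 48 h; a lower number here means a stronger inhibitor, a higher number a weaker inhibitor. Compound 1 `COc1cc(NC(=O)n2cc(-c3ccc(O)cc3)n(-c3cc(OC)c(OC)c(OC)c3)c2=O)cc(OC)c1OC` sits at a limit of the assay, > 50000 nM, and not at a number. Within the data shown here, compound 2 `COc1cc(-n2c(-c3ccc(Br)cc3)cn(C(C)=O)c2=O)cc(OC)c1OC` gives 900 nM, the only true number so far. Compound 3 `COc1cc(-n2c(-c3ccc(F)cc3F)cn(C(C)=O)c2=O)cc(OC)c1OC` carries 2,4-difluorophenyl in place of 4-bromophenyl on an aromatic carbon. Among the measured compounds shown here, no measured step covers this change, so the only anchor is compound 2 at 900 nM. The expected step of a 1.3-fold higher number from compound 2 to compound 3 (0.12 log units; within the scatter) stays within the scatter, with no firm direction. For compound 3 the estimated value is 1200 nM, with a range of 300 nM to 5000 nM.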

Compound 3, half-maximal inhibitory concentration: > 50000 nM
Compound 3 ended at the assay's limit (the forecaster's own chance of this, stated with the estimate: 3%); at least 41-fold (1.61 log units) between middle value and limit.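

In this assay, 2,4-difluorophenyl in place of 4-bromophenyl gives an at least 55-fold higher number from compound 2 to compound 3 (1.74 log units; beyond the scatter), so at this position the result depends on which of these two aryl groups is carried. Compound 3 sits at a limit, so this step has a floor and no true size: the limit of > 50000 nM in this assay, at which 2 of the 3 values shown sit.

The swap removes the bromine and adds two fluorines in one change, leaving open which of these matters. A plain phenyl or a chlorophenyl group at this position would help separate the two.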